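From 4-fluorophenyl to 4-bromo-2-fluorophenyl on the aromatic nitrogen

The source may report more compounds than this note shows. Statements on the series, on what has been measured and on what is new or still open speak of the compounds shown alone.

Measured so far, in a functional assay on A549 cells (Homo sapiens) for antiproliferative activity, read by MTT assay, with a stated time of 72 h; on this read-out lower numbers stand for stronger inhibition and higher numbers for weaker inhibition:
compound 1, `CNC(=O)c1cc(Oc2ccc(NC(=O)c3cc4cccnc4n(-c4ccccc4)c3=O)cc2)ccn1`, gives 200 nM;
compound 2, `CNC(=O)c1cc(Oc2ccc(NC(=O)c3cc4cccnc4n(-c4ccccc4F)c3=O)cc2)ccn1`, gives 610 nM;
compound 3, `CNC(=O)c1cc(Oc2ccc(NC(=O)c3cc4cccnc4n(-c4ccc(F)cc4)c3=O)cc2)ccn1`, gives 110 nM.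

Compound 3 has the lowest number of the three, though its gap to compound 1 is within the scatter, and only its step from compound 2 stands clear: a 5.5-fold lower number from compound 2 to compound 3 (0.74 log units; beyond the scatter).

The next compound, compound 4, is `CNC(=O)c1cc(Oc2ccc(NC(=O)c3cc4cccnc4n(-c4ccc(Br)cc4F)c3=O)cc2)ccn1`. It differs from compound 3 in one place: 4-bromo-2-fluorophenyl in place of 4-fluorophenyl on an aromatic nitrogen.

Going by the values given here, two measured steps bear on this. The fluoro that enters on the same ring position in compound 4 was tried alone in compound 2, where a 3.1-fold higher number from compound 1 to compound 2 (0.48 log units; beyond the scatter). The fluoro that compound 4 gives up sat in compound 3, where a 1.8-fold lower number from compound 1 to compound 3 (0.26 log units; within the scatter). The bromo has no precedent among these compounds, so its contribution is unknown. Since the step from compound 1 to compound 2 raised the number beyond the scatter, compound 4 is expected to sit somewhat higher than compound 3, by about a 2.7-fold higher number from compound 3 to compound 4 (0.44 log units; beyond the scatter), with wide uncertainty from the bromo. For compound 4 in this assay the estimate is 300 nM, between 100 nM and 900 nM.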

Compound 4, half-maximal inhibitory concentration: 1420 nM
Beside the measured number, compound 4's estimate is 4.7-fold (0.68 log units) below it; measured number outside the range, above it.
By their numbers in this assay, from the lowest: compounds 3 and 1 (each within the scatter of the next); then compound 2; then compound 4.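

In this assay, 4-bromo-2-fluorophenyl on the aromatic nitrogen gives the largest step among these compounds, a 13-fold higher number from compound 3 to compound 4 (1.11 log units; beyond the scatter) and the only one printed as large, leaving compound 4 the weakest of the four. Bromo added to the 2-fluorophenyl ring gives a 2.3-fold higher number from compound 2 to compound 4 (0.37 log units; beyond the scatter) and so raises the number beyond the scatter, whereas the fluoro of 4-fluorophenyl gave a 1.8-fold lower number from compound 1 to compound 3 (0.26 log units; within the scatter) and stayed within it. Set against the plain phenyl, the full change gives a 7.1-fold higher number from compound 1 to compound 4 (0.85 log units; beyond the scatter) as its overall result, and both single additions on the way to it, the fluoro of compound 2 and then the bromo of compound 4, raise the number.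

No measurement at hand gives a reason for these rises. Left open is whether a 4-bromophenyl group without the fluoro, or a 4-chlorophenyl or 4-methoxyphenyl group, on the same nitrogen would stay close to compound 3 or climb towards compound 4.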